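The source may report more compounds than this note shows. Statements on the series, on what has been measured and on what is new or still open speak of the compounds shown alone.

Of the compounds shown here, two have been measured in a functional assay on PANC-1 cells (Homo sapiens) for inhibition, read by MTT assay, with a stated time of 24 h, tested at 10 uM; on this read-out higher numbers stand for more inhibition at the one concentration tested (going by the name of the read-out) and lower numbers for less inhibition: compound 1 `CC(C)=CCC1Cc2c(OCCCNC(=O)c3ccco3)cc(=O)n(CCCO)c2CC1(C)C` gives 2.1%, and compound 2 `CC(C)=CCC1Cc2c(OCCCNC(=O)c3ccc([N+](=O)[O-])cc3)cc(=O)n(CCCO)c2CC1(C)C` gives 49.9%.

For the measured compounds named here, compound 2 stands highest of the two numbers, with compound 1 its only neighbour. Going by the values given here, the one measured step, a number 47.8 percentage points higher from compound 1 to compound 2 (beyond the scatter), came from a swap of the aryl group on the carbonyl carbon.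

Compound 3 `COc1ccc(OCCCOc2cc(=O)n(CCCO)c3c2CC(CC=C(C)C)C(C)(C)C3)cc1` is not yet measured. It differs from compound 2 by 4-methoxyphenoxy in place of ((4-nitrophenyl)carbonyl)amino on a saturated chain carbon, three bonds along the chain from an oxygen on an aromatic ring. Among the compounds with values here, no measured step replaces the whole amide by an ether, so the direction is uncertain; a step of a number 24.9 percentage points lower from compound 2 to compound 3 (beyond the scatter) is expected, with wide doubt. Compound 3 is estimated at 25%, between 3% and 55%.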

Compound 3, a percentage reported as inhibition, at one concentration (the size of the read-out at that concentration, not a potency): 47.7%
Compound 3: the middle estimate sits 22.7 percentage points below what was measured; the measured number falls inside the stated range.
By their numbers in this assay, from the lowest: compound 1; then compounds 3 and 2 (each within the scatter of the next).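

Compound 3 shows that the amide link on this chain is not required for inhibition at the level of compound 2: 4-methoxyphenoxy in place of ((4-nitrophenyl)carbonyl)amino gives a number 2.2 percentage points lower from compound 2 to compound 3 (within the scatter). Set against the furan amide, the same group gives a number 45.6 percentage points higher from compound 1 to compound 3 (beyond the scatter), so compound 1 remains the only low member of the three. Nothing at hand explains these numbers.

As far as these compounds go, what a morpholine amine or a carboxylic acid at the end of this chain would give stays open. So does whether a 4-methoxyphenyl amide would match the ether.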